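This account rests on a few compounds, and the source may have more. Where it says the series, first, only, none or still open, it means among the compounds named here.

Working notes on the series. Compound 1 `C/C(=C\CC/C(C)=C/CC[C@@H]1[C@@]2(C)CCC(=O)C(C)(C)[C@H]2CC[C@@]1(C)O)CC/C=C(\C)C(=O)OCc1cn(-c2ccccc2C)nn1` carries a 2-methylphenyl on an aromatic nitrogen. In a functional assay on A549 cells (Homo sapiens) for antiproliferative activity, read by MTT assay, with a stated time of 48 h (a higher number here means a weaker inhibitor, a lower number a stronger inhibitor), compound 1 gives > 150000 nM, a limit of the assay rather than a number. Compound 2 `C/C(=C\CC/C(C)=C/CC[C@@H]1[C@@]2(C)CCC(=O)C(C)(C)[C@H]2CC[C@@]1(C)O)CC/C=C(\C)C(=O)OCc1cn(-c2ccc(C(F)(F)F)cc2)nn1` carries 4-(trifluoromethyl)phenyl in place of 2-methylphenyl on that aromatic nitrogen. In this assay compound 2 gives > 150000 nM, again a limit. Compound 3 `C/C(=C\CC/C(C)=C/CC[C@@H]1[C@@]2(C)CCC(=O)C(C)(C)[C@H]2CC[C@@]1(C)O)CC/C=C(\C)C(=O)OCc1cn(-c2ccccc2C(F)(F)F)nn1` carries trifluoromethyl in place of methyl on an aromatic carbon relative to compound 1. In this assay compound 3 gives > 150000 nM, which is also a limit.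

Compound 3 therefore stands at the limit, with no number of its own, and the same holds for the two compounds beside it. The steps a step that the two limits leave unreadable from compound 1 to compound 2, a step that the two limits leave unreadable from compound 1 to compound 3 and a step that the two limits leave unreadable from compound 2 to compound 3 cannot be sized, because of the limit of > 150000 nM in this assay, at which 3 of the 3 values shown sit.

Compound 4 `C/C(=C\CC/C(C)=C/CC[C@@H]1[C@@]2(C)CCC(=O)C(C)(C)[C@H]2CC[C@@]1(C)O)CC/C=C(\C)C(=O)OCc1cn(-c2ccccc2)nn1` is the next point: hydrogen in place of trifluoromethyl on an aromatic carbon. The steps that touch the same region, from compound 1 to compound 3 and from compound 2 to compound 3, bear on this change, but both are unreadable at the limit. No readable step exists in the series, so no direction can be inferred; the expectation is simply that compound 4 will again sit at or near the limit, the step that the limit leaves unreadable from compound 3 to compound 4 being expected as no more than the scatter. Compound 4 is estimated at 200000 nM in this assay, within 60000 nM to 600000 nM.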

Compound 4, half-maximal inhibitory concentration: > 150000 nM
Compound 4 was reported as a limit; the forecaster's own chance of this, stated with the estimate: 85%; the middle value does not contradict the limit.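

Compound 4 gives > 150000 nM in this assay, again a limit. No step from compound 1, compound 2 or compound 3 to compound 4 can be read, because all of them share one limit: the limit of > 150000 nM in this assay, at which 4 of the 4 values shown sit.

The compounds shown leave open whether any change to the phenyl on the aromatic nitrogen affects antiproliferative activity, and in which direction.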